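The compounds below may be only part of what the source reports. "The series", "measured", "known", "first", "only" and "open" are said of these compounds alone.

Measured compounds:
Compound 1 `N/C(=N\NC(=S)N1CCCCCC1)c1ccccn1`: in a functional assay on MCF7 cells (Homo sapiens) for cytotoxicity, read by MTT assay, with a stated time of 72 h, tested at 1 uM (on this read-out lower numbers stand for less inhibition of growth and higher numbers for more inhibition of growth at the one concentration tested), compound 1 gives 25.3%
Compound 2 `N/C(=N\NC(=S)N1CCOCC1)c1ccccn1`: in this assay compound 2 gives 14.7%
Compound 3 `Cc1ccnc(/C(N)=N/NC(=S)N2CCSCC2)c1`: in this assay compound 3 gives 3.89%

Of the three measured values in this assay, compound 3 stands lowest. Its nearest neighbour is compound 2, whose number lies higher by a margin beyond the usual scatter, and compound 1 lies further still above it, again beyond the scatter. Compound 3 thus marks the bottom of the measured range, and nothing in these three numbers connects the change from one ring to another with a counted step, since no two of them differ in a single place.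

Compound 4 `Cc1ccnc(/C(N)=N/NC(=S)N2CCCC2)c1` has not yet been measured. It differs from compound 3 in one place: pyrrolidin-1-yl in place of thiomorpholin-4-yl on a thiocarbonyl carbon. Among the measured compounds shown here, no pair of measured compounds isolates such a change. For the measured compounds named here, no measured step can therefore be carried over. Compound 1, which carries an all-carbon ring on the thiocarbonyl carbon, gives 25.3%, the highest of the set, and this is the only hint available.

On that basis compound 4 is expected to sit somewhat above compound 3, with the step of a number 8.1 percentage points higher from compound 3 to compound 4 (within the scatter) judged as small and possibly within the scatter. The estimate for compound 4 in this assay is 12%, with a range from 0% to 30%.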

Compound 4, percent growth inhibition at one concentration: 49%
Compound 4: the middle estimate sits 37 percentage points below what was measured, outside the stated range (above it).
By their numbers in this assay, from the lowest: compound 3; then compound 2; then compound 1; then compound 4.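

In this assay, among the compounds shown here, the exchange of thiomorpholin-4-yl for pyrrolidin-1-yl on a thiocarbonyl carbon gives a number 45.1 percentage points higher from compound 3 to compound 4 (beyond the scatter) and is the first change in one place that can be read in this set, showing that the group at this position can strongly alter growth inhibition at the one concentration tested. The change both removes the ring sulfur and replaces a six-membered ring holding 2 hetero atoms with a five-membered ring holding 1 hetero atom, and this single step does not separate those differences from one another. No measurement at hand accounts for the size of the step.

The compounds shown leave open whether the ring sulfur or the ring size matters more, a question that a piperidin-1-yl group on the thiocarbonyl carbon, paired with compound 3 and compound 4 on the same core, could help to answer. They also leave open whether an open-chain diethylamino group at this place would retain the growth inhibition of compound 4 and whether the step would carry over to the core of compound 1.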